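A few compounds are considered here, and "the series" means these few. Any claim that something is new, unique, unknown or untested is made for them only; others in the source may bear on it.

Working notes on the series.

Compound 1 `N#Cc1c(Nc2ccccc2)c(Cl)c2nc(N)nc(N)c2c1F` gives 47 ug/mL in a functional assay on HL-60 cells (Homo sapiens) for cytotoxicity, read by MTT assay; a lower number here means a stronger inhibitor, a higher number a weaker inhibitor. Compound 2 `N#Cc1c(Nc2ccccc2)c(F)c2nc(N)nc(N)c2c1F` is the fluoro analogue of compound 1. In this assay compound 2 gives 40 ug/mL. The step between them, a 1.2-fold lower number from compound 1 to compound 2 (0.07 log units; within the scatter), is the change (fluoro in place of chloro on an aromatic carbon); the two numbers lie within the scatter of each other, so no order can be read from this pair.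

Compound 3 `N#Cc1c(NCc2ccccc2)c(Cl)c2nc(N)nc(N)c2c1NCc1ccccc1` carries a different core, and the difference between the core of compound 3 and the core of compound 1 is not broken down here. In this assay, within the data shown here, compound 3 gives 8.5 ug/mL, the lowest of the three numbers so far, beyond the scatter from both compound 1 and compound 2.

Compound 4 `N#Cc1c(NCc2ccccc2)c(F)c2nc(N)nc(N)c2c1NCc1ccccc1` is not yet measured. It differs from compound 3 by fluoro in place of chloro on an aromatic carbon. This is the same kind of change as from compound 1 to compound 2, though the surroundings differ: in compound 1 the carbon is ortho to an anilino group and para to a fluoro group, whereas in compound 3 it is ortho to a benzylamino group and para to a benzylamino group.

Among the measured compounds shown here, the only precedent for this change is a 1.2-fold lower number from compound 1 to compound 2 (0.07 log units; within the scatter), a step within the scatter. On that basis the step from compound 3 to compound 4 in this assay is expected to be small as well, about a 1.1-fold lower number from compound 3 to compound 4 (0.05 log units; within the scatter). For the measured compounds named here, compound 4 is therefore estimated at 7.5 ug/mL in this assay, with a likely range from 4 ug/mL to 14 ug/mL; the wider range reflects that the single precedent comes from a different core.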

Compound 4, half-maximal inhibitory concentration: 7.2 ug/mL
The estimate for compound 4 lay 1.0-fold (0.02 log units) above the measured number; the range from low to high includes it.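

In this assay, fluoro in place of chloro on the aromatic carbon gives a 1.2-fold lower number from compound 3 to compound 4 (0.07 log units; within the scatter), so no order can be read between this pair. Set beside the earlier step, the change carries from one core to the other with no difference that can be resolved: the same change on two cores in this assay, a 1.2-fold lower number (0.07 log units; within the scatter) from compound 1 to compound 2 and a 1.2-fold lower number (0.07 log units; within the scatter) from compound 3 to compound 4, 1.0-fold (0.00 log units) apart, within the scatter of two such steps. Among these compounds, this shows that on both cores the exchange of these two halogens leaves the number within the scatter, but it rests on only two pairs in one cell assay and does not show that the same would hold on any other core or in any other read-out.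

Open, going by these compounds, is whether a different group on this aromatic carbon, such as bromo, methoxy or an amine, would move the number beyond the scatter on either core. Also open, on these data alone, is whether the step would stay as small with a longer chain, such as phenethylamino, in place of the benzylamino groups that flank this carbon in compound 3 and compound 4.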